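The compounds below may be only part of what the source reports. "The series", "measured", "known", "first", "only" and "open" are said of these compounds alone.

Measured compounds:
Compound 1, `COc1cc(NC(=O)Nc2cc(Nc3cc(C(F)(F)F)ccc3OC)ncn2)cc(OC)c1` — in a functional assay on HCC827 cells (Homo sapiens) for inhibition, read by MTT assay, with a stated time of 48 h, tested at 10 uM (a lower number here means less inhibition, a higher number more inhibition at the concentration tested (going by the name of the read-out)), compound 1 gives 59.7%
Compound 2, `COc1cc(Nc2cc(NC(=O)Nc3c(Cl)cccc3Cl)ncn2)cc(OC)c1` — in this assay compound 2 gives 73.7%

Compound 2 stands highest of the two numbers on hand. Its nearest neighbour is compound 1, whose number is lower, a gap that lies beyond the usual scatter of repeated measurements. Among the measured compounds shown here, the two compounds differ in more than one place, so their pair gives no single-change step; only the two values themselves can be read.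

The step of interest leads from compound 2 to compound 3, `COc1cc(Nc2cc(NC(=O)Nc3c(Cl)cccc3Cl)ncn2)cc(C(F)(F)F)c1`, which has not yet been measured in this assay. The change is a small one: trifluoromethyl in place of methoxy on an aromatic carbon. For the measured compounds named here, no measured pair isolates such an exchange, so there is no step on hand from which to read its size.

Compound 3 is expected to land close to compound 2, with a step of a number 7.7 percentage points lower from compound 2 to compound 3 (within the scatter) that may well fall within the scatter. The estimate for compound 3 in this assay is 66%, within a range of 45% to 85%.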

Compound 3, a percentage reported as inhibition, at one concentration (the size of the read-out at that concentration, not a potency): 57.7%
Estimate against measurement, compound 3: 8.3 percentage points above; low and high end bracket the measured number.
By their numbers in this assay, from the lowest: compounds 3 and 1 (each within the scatter of the next); then compound 2.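

In this assay, among the compounds shown here, the first single-change step on hand is a number 16 percentage points lower from compound 2 to compound 3 (beyond the scatter), which shows that this position, on a six-membered aromatic ring of carbon only, meta to a large group and meta to a methoxy group, is not indifferent to the group it carries. For the compounds shown here, the earlier compounds could not show this, since they differed in more than one place and gave only two separate values. A single exchange still cannot separate the differences between the two groups, as trifluoromethyl brings 4 heavy atoms and 0 hydrogen-bond acceptors where methoxy had 2 heavy atoms and 1 hydrogen-bond acceptor, and nothing on hand offers an explanation for the step.

The compounds shown leave open whether another group at this position, such as an amine, a carboxylic acid or a longer chain like ethoxy, would keep the number near that of compound 2 or move it further. They also leave open whether the same exchange would give a step of similar size on compound 1, or at the methoxy group that remains in compound 3.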